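The source may report more compounds than this note shows. Statements on the series, on what has been measured and on what is new or still open speak of the compounds shown alone.

Measured compounds:
Compound 1, `COc1ccc(-c2nn3cc(-c4cccc(N)c4)nc3s2)cc1OC`: 14000 nM
Compound 2, `C=C(Br)C(=O)Nc1cccc(-c2cn3nc(-c4ccc(OC)c(OC)c4)sc3n2)c1`: 380 nM
Compound 3, `C=C(Br)C(=O)Nc1cccc(-c2cn3c(-c4ccc(OC)cc4)csc3n2)c1`: 500 nM

In a functional assay on CCRF-CEM cells (Homo sapiens) for inhibition, read by cell counting, with a stated time of 3 days (on this read-out higher numbers stand for weaker inhibition and lower numbers for stronger inhibition), compound 2 gives the lowest number of the three. Compound 3 lies within the scatter of compound 2, so the two cannot be set in order. Compound 1, with a hydrogen on the aromatic nitrogen, stands far apart: the step of a 37-fold lower number from compound 1 to compound 2 (1.57 log units; beyond the scatter) is the one large effect in this small set.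

Compound 4, `C=C(Br)C(=O)Nc1cccc(-c2cn3nc(CCc4ccccc4)sc3n2)c1`, is not yet measured. It differs from compound 2 by phenethyl in place of 3,4-dimethoxyphenyl on an aromatic carbon. Within the data shown here, no measured pair bears directly on this change: the only step on record concerns the amide group, which compounds 2 and 4 share, and compounds 2 and 3 differ in both the aryl group and the core, so they show only that two methoxy-bearing aryl groups give similar numbers. Without a guiding step, and with the 3,4-dimethoxyphenyl replaced by phenethyl, the author expects a moderate rise, a 3.2-fold higher number from compound 2 to compound 4 (0.50 log units; beyond the scatter). For compound 4 the estimate in this assay is 1200 nM, within 300 nM to 5000 nM.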

Compound 4, half-maximal inhibitory concentration: 4200 nM
Compound 4: the middle estimate sits 3.5-fold (0.54 log units) below what was measured; the range from low to high includes it.
By their numbers in this assay, from the lowest: compounds 2 and 3 (each within the scatter of the next); then compound 4; then compound 1.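

In this assay, putting phenethyl in place of 3,4-dimethoxyphenyl on the aromatic carbon of the five-membered ring gives an 11-fold higher number from compound 2 to compound 4 (1.04 log units; beyond the scatter) and thus a large effect at a position the earlier step did not touch. With the (1-bromoethenyl)carbonyl group of compound 2 kept, compound 4 still reads 4200 nM, so that group alone does not set the number in this series. The data shown offer no explanation for this step.

The change replaces the methoxy groups and the direct attachment of the aromatic ring in one move, so the compounds shown cannot tell which of the two matters. Going by these compounds, how an unsubstituted phenyl or a benzyl group would read at this carbon remains open.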